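Swapping Fluoro for Methyl on a Potent Compound

The source may hold more compounds than are shown below. What is called first, only, known or untested is meant among the compounds shown, and "the series" means these compounds.

Measured in a functional assay on HCT-116 cells (Homo sapiens) for antiproliferative activity; on this read-out lower numbers stand for stronger inhibition of growth and higher numbers for weaker inhibition of growth:
- compound 1 `Cc1cc(C)c2c(O)cc(-c3cccc(F)c3)nc2n1`: < 10 nM
- compound 2 `Cc1ccnc2nc(-c3ccc4ccccc4c3)cc(O)c12`: 427 nM
- compound 3 `Cc1cccc(-c2cc(O)c3cc(C)cnc3n2)c1`: 407 nM

Compound 1 gives < 10 nM, and this is a limit of the assay, not a number. Its true value is therefore unknown, and any change from it can only be judged loosely.

Compound 4 `Cc1cccc(-c2cc(O)c3c(C)cc(C)nc3n2)c1` keeps the core of compound 1 but has methyl in place of fluoro on an aromatic carbon, on a six-membered aromatic ring of carbon only, meta to a large group (methyl in place of fluoro on an aromatic carbon). Within the data shown here, no measured pair shows this swap on its own. The nearest clue is compound 3, which also has a methyl on its carbon-only ring and gives 407 nM, although its core differs from that of compound 4.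

That clue points to some loss of growth inhibition in this assay, though a modest one, as the core of compound 1 is retained. The expected change is an at least 4.0-fold higher number from compound 1 to compound 4 (0.60 log units; beyond the scatter).

For compound 4 the estimate is 40 nM, with an expected range of 10 nM to 250 nM.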

Compound 4, concentration for 50% growth inhibition: 17800 nM
Estimate against measurement, compound 4: 450-fold (2.65 log units) below; the measured number lies above the stated range.
By their numbers in this assay, from the lowest: compounds 3 and 2 (each within the scatter of the next); then compound 4. At a limit, below all of these: compound 1.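

In this assay, exchanging fluoro for methyl on the carbon-only ring gives an at least 1700-fold higher number from compound 1 to compound 4 (3.25 log units; beyond the scatter), so on the core of compound 1 this place, meta to a large group, accepts methyl far less well than fluoro. The swap leaves the count of heavy atoms unchanged, which shows that replacing one heavy atom here can separate strong from weak inhibition of growth, something compounds 2 and 3 could not show with their different cores. Compound 1 gives < 10 nM, which is a limit of the assay and not a number, so the full size of this step cannot be read: the limit of < 10 nM in this assay, at which 1 of the 4 values shown sits.

The compounds shown leave open whether fluoro is unusually favourable at this place or methyl is unusually poor. A chloro, methoxy or hydroxyl group on the same carbon would help to tell these two readings apart.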